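This account rests on a few compounds, and the source may have more. Where it says the series, first, only, none or still open, it means among the compounds named here.

Compound 1 `Nc1cccc(-c2cn3c(-c4ccc(Cl)cc4)csc3n2)c1` gives 17000 nM in a functional assay on HeLa cells (Homo sapiens) for inhibition, read by cell counting, with a stated time of 4 days; a higher number here means a weaker inhibitor, a lower number a stronger inhibitor.
Compound 2 `COc1ccc(-c2csc3nc(-c4cccc(N)c4)cn23)cc1` gives 19000 nM in this assay.
Compound 3 `C=C(Br)C(=O)Nc1cccc(-c2cn3nc(-c4ccc(OC)cc4)sc3n2)c1` gives 2300 nM in this assay.

Compound 3 gives the lowest number of the three, and compound 1 and compound 2 give numbers within the usual scatter of each other. Between them stands one change, (chloro in place of methoxy on an aromatic carbon), which made the step of a 1.1-fold lower number from compound 2 to compound 1 (0.05 log units; within the scatter).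

Compound 4 `C=C(Br)C(=O)Nc1cccc(-c2cn3nc(-c4ccc(Cl)cc4)sc3n2)c1` has not yet been measured. It differs from compound 3 by chloro in place of methoxy on an aromatic carbon, the same kind of change. The difference between the core of compound 2 and the core of compound 3 is not broken down here.

For compound 4 in this assay, a step of a 1.1-fold lower number from compound 3 to compound 4 (0.04 log units; within the scatter) is expected, because the earlier step of this kind was a 1.1-fold lower number from compound 2 to compound 1 (0.05 log units; within the scatter). Compound 4 is therefore estimated at 2100 nM, between 1000 nM and 5000 nM.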

Compound 4, half-maximal inhibitory concentration: 3000 nM
Compound 4: the middle estimate sits 1.4-fold (0.15 log units) below what was measured, and the stated range covers the measured number.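

In this assay the change from 4-methoxyphenyl to 4-chlorophenyl gave a 1.3-fold higher number from compound 3 to compound 4 (0.12 log units; within the scatter). Set beside the earlier step on the other core, the two steps agree: the same change on two cores in this assay, a 1.1-fold lower number (0.05 log units; within the scatter) from compound 2 to compound 1 and a 1.3-fold higher number (0.12 log units; within the scatter) from compound 3 to compound 4, 1.5-fold (0.16 log units) apart, within the scatter of two such steps. This shows that the change carried over between these two cores, in the sense that neither step stands beyond the scatter of repeated measurements. It does not show that the same would hold on a further core, and two pairs in which the change does little say nothing about how a group with a larger step would carry over.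

The compounds shown leave open what other groups at this place on the phenyl ring would do, such as an amine, a carboxylic acid or a longer chain.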